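Swapping the Serine Side Chain for Valine

A few compounds are considered here, and "the series" means these few. Any claim that something is new, unique, unknown or untested is made for them only; others in the source may bear on it.

Measured so far, in a functional assay on the whole organism (Tail, strain ICR) with Mus musculus as the target, in the tail flick test, with a stated time of 90 min, at a dose of 25 umol/kg by the oral route; a higher number here means a stronger effect of the compound at the dose given, a lower number a weaker effect:
Compound 1, `O=C(CN(c1nc(Cl)nc2[nH]cnc12)C1CC1)N[C@@H](CO)C(=O)OCc1ccccc1`, gives 34.5%.
Compound 2, `O=C(CN(c1nc(Cl)nc2[nH]cnc12)C1CC1)N[C@@H](CO)C(=O)O`, gives 43.9%.
Compound 3, `O=C(CN(c1nc(Cl)nc2[nH]cnc12)C1CC1)N[C@@H](CCC(=O)OCc1ccccc1)C(=O)OCc1ccccc1`, gives 50%.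

Compound 2 sits neither clearly above nor clearly below its neighbours: the step of a number 9.4 percentage points higher from compound 1 to compound 2 (within the scatter) is within the scatter, and compound 2 and compound 3 differ by a gap that is also within the scatter, so no order among the three is secure.

Compound 4, `CC(C)[C@H](NC(=O)CN(c1nc(Cl)nc2[nH]cnc12)C1CC1)C(=O)O`, has not yet been measured. It differs from compound 2 by isopropyl in place of hydroxymethyl on a saturated chain carbon bound to an amide-type nitrogen and a carbonyl carbon. Among the compounds with values here, no measured step changes this exact position. The nearest hint is a number 15.5 percentage points higher from compound 1 to compound 3 (beyond the scatter), where a hydroxy group gave way to a larger carbon-bearing group on the side chain and the number rose modestly; the step of a number 9.4 percentage points higher from compound 1 to compound 2 (within the scatter) changed a different part and stayed within the scatter. On that basis a small rise or no change beyond the scatter is expected, a number 4.1 percentage points higher from compound 2 to compound 4 (within the scatter), giving an estimated value for compound 4 of 48%, between 30% and 66%.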

Compound 4, a percentage reported as activity, at one dose (the size of the read-out at that dose, not a potency): 30.3%
Compound 4: the middle estimate sits 17.7 percentage points above what was measured, and the stated range covers the measured number.
By their numbers in this assay, from the lowest: compounds 4, 1, 2 and 3 (each within the scatter of the next, the first and the last beyond it).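

In this assay, isopropyl in place of hydroxymethyl on a saturated chain carbon bound to an amide-type nitrogen and a carbonyl carbon gives a number 13.6 percentage points lower from compound 2 to compound 4 (beyond the scatter), the first step measured at this exact position with the rest of the molecule unchanged. Side-chain changes at this carbon can therefore lower the number as well as raise it, since a number 15.5 percentage points higher from compound 1 to compound 3 (beyond the scatter) went the other way, though with a different entering group and with benzyl esters present. The leaving hydroxymethyl has one hydrogen-bond donor and one acceptor and the entering isopropyl has neither, but nothing available shows whether that difference accounts for the fall.

The compounds shown leave open how a plain methyl, a longer chain or an amine would fare on this carbon. They also leave open whether isopropyl would lower the number by a similar amount when the benzyl ester of compound 1 is kept.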